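The source may report more compounds than this note shows. Statements on the series, on what has been measured and on what is new or still open speak of the compounds shown alone.

Compound 2 `CCN(CC)C(=O)Oc1ccc(-c2cc(=O)c3c(O)c(O)c(O)cc3o2)cc1` carries a carbamate on the shared core, and in a physicochemical assay for solubility, read by spectrophotometry (a higher number here means a more soluble compound, a lower number a less soluble compound), compound 2 gives 9.23 ug/mL. Among the two measured compounds this is the highest number, but the nearest one, compound 1 `CC(C)N(C(=O)Oc1ccc(-c2cc(=O)c3c(O)c(O)c(O)cc3o2)cc1)C(C)C`, stands close: in this assay compound 1 gives 8.67 ug/mL, and the step of a 1.1-fold higher number from compound 1 to compound 2 (0.03 log units; within the scatter) stays within the scatter. Compound 3 `O=C(COc1ccc(-c2cc(=O)c3c(O)c(O)c(O)cc3o2)cc1)N1CCOCC1` differs from compound 2 by ((morpholin-4-yl)carbonyl)methyl in place of diethylcarbamoyl on an oxygen on an aromatic ring. Going by the values given here, the only measured step, from compound 1 to compound 2, swaps one amine portion of the carbamate for another and so does not cover the change to an ether linked to a morpholine amide; it offers no guide to direction. Among the compounds with values here, with no step bearing on the change, compound 3 is expected to land near compound 2, giving an estimated 10 ug/mL, between 4 ug/mL and 25 ug/mL, an expected step of a 1.1-fold higher number from compound 2 to compound 3 (0.03 log units; within the scatter).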

Compound 3, solubility: 9.45 ug/mL
Estimate against measurement, compound 3: 1.1-fold (0.02 log units) above, and the stated range covers the measured number.
By their numbers in this assay, from the lowest: compounds 1, 2 and 3 (each within the scatter of the next).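

On the oxygen on an aromatic ring, the earlier pair compared only two amine portions of a carbamate, whereas compound 3 places ((morpholin-4-yl)carbonyl)methyl there, bringing a six-membered non-aromatic ring and one more hydrogen-bond acceptor than diethylcarbamoyl. In this assay this replacement gives a 1.0-fold higher number from compound 2 to compound 3 (0.01 log units; within the scatter) and, measured against the diisopropyl carbamate, a 1.1-fold higher number from compound 1 to compound 3 (0.04 log units; within the scatter) so even this broader replacement cannot be told apart from either carbamate. Nothing available here accounts for this result.

On these data alone, compound 3 alters the link to the oxygen and the amide portion together, so the separate contribution of each remains unknown. As far as these compounds go, whether a carboxylic acid or a free amine at the end of a longer chain on this oxygen would move the number beyond the scatter also remains open.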